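Replacing an amide with an aryl ring on the shared core

This account rests on a few compounds, and the source may have more. Where it says the series, first, only, none or still open, it means among the compounds named here.

Compounds measured so far:
compound 1, `CNC(=O)c1cncc(NS(=O)(=O)c2cc(Cl)ccc2OC)c1`, 109 nM
compound 2, `COc1ccc(C(N)=O)cc1S(=O)(=O)Nc1cccnc1`, 1490 nM
compound 3, `COc1ccc(S(=O)(=O)Nc2cccnc2)c(OC)c1`, 10300 nM

These three compounds were tested in an assay on isolated protein for inhibition of alkaline phosphatase, tissue-nonspecific isozyme (Homo sapiens); a lower number here means a stronger inhibitor, a higher number a weaker inhibitor. Compound 1 stands lowest of the three numbers: compound 2 lies well beyond the scatter above it, and compound 3 lies further still above it, so compound 1 is the strongest inhibitor of the set. No pair of these compounds differs in only one place, so no single step between measured compounds can be read off.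

The next compound, compound 4, `COc1ccc(Cl)cc1S(=O)(=O)Nc1cncc(-c2ccc(C)cc2)c1`, is derived from compound 1 by a single change: 4-methylphenyl in place of methylcarbamoyl on an aromatic carbon. The group that leaves carries a hydrogen-bond donor and a hydrogen-bond acceptor; the group that enters is an aromatic ring of carbon only, with neither. The change sits two atoms from the ring nitrogen of the shared core.

Nothing measured here shows what a 4-methylphenyl does at that position, so the expectation rests on compound 1 alone, whose value of 109 nM is the starting point. The account expects a small to moderate loss in this assay, a step of a 2.8-fold higher number from compound 1 to compound 4 (0.44 log units; beyond the scatter), beyond the scatter but not large. For compound 4 the estimate is 300 nM, with a range from 60 nM to 1500 nM.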

Compound 4, half-maximal inhibitory concentration: 147 nM
Estimate against measurement, compound 4: 2.0-fold (0.31 log units) above, within the range that was stated.
By their numbers in this assay, from the lowest: compounds 1 and 4 (each within the scatter of the next); then compound 2; then compound 3.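

In this assay, a 1.3-fold higher number from compound 1 to compound 4 (0.13 log units; within the scatter) stays within the scatter, so the values of the two compounds cannot be told apart at this position, two atoms from the ring nitrogen. The methylcarbamoyl carries a hydrogen-bond donor and a hydrogen-bond acceptor and the 4-methylphenyl carries neither, so this pair shows that a value at the level of compound 1 does not depend on either feature of the leaving group here, and that an aromatic ring of carbon only, with more heavy atoms, is accepted in its place. Nothing measured here accounts for why two such different groups read alike.

The compounds shown leave open how far this acceptance extends, for instance whether an amine, a carboxylic acid or a longer chain at the same aromatic carbon would also read alike with compound 1. On these data alone, it also remains open what the methyl of the 4-methylphenyl contributes, a question that a plain phenyl at this position would address.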